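Swapping fluoro for methoxy on the outer aromatic ring

This account rests on a few compounds, and the source may have more. Where it says the series, first, only, none or still open, it means among the compounds named here.

Of the compounds shown here, three sharing one core have been measured in a functional assay on PC-12 cells (Rattus norvegicus) for cytotoxicity, read by MTT assay, with stated times of 2 h and 24 h, tested at 5 uM; a higher number here means a stronger effect of the compound at the concentration tested, a lower number a weaker effect. Compound 1 `CC(C)(C)c1ccc(-n2nc(-c3ccc(C(F)(F)F)cc3O)nc2-c2ccccc2O)cc1` gives 77.8%, compound 2 `Oc1cc(C(F)(F)F)ccc1-c1nc(-c2ccccc2O)n(-c2ccc(F)cc2)n1` gives 86.7%, and compound 3 `Oc1cc(C(F)(F)F)ccc1-c1nc(-c2ccccc2O)n(-c2ccc(C(F)(F)F)cc2)n1` gives 90.5%. Compound 2 stands second of the three, yet a number 8.9 percentage points higher from compound 1 to compound 2 (within the scatter) and a number 3.8 percentage points higher from compound 2 to compound 3 (within the scatter) both lie within the scatter, and only a number 12.7 percentage points higher from compound 1 to compound 3 (beyond the scatter) reaches beyond it. Compound 4 `COc1ccc(-n2nc(-c3ccc(C(F)(F)F)cc3O)nc2-c2ccccc2O)cc1` differs from compound 2 at the same place where these three differ: methoxy in place of fluoro on an aromatic carbon. Since tert-butyl, fluoro and trifluoromethyl at this spot gave numbers close together, a fourth group there is expected to leave this assay roughly unchanged. Compound 4 is therefore estimated at 84%, between 70% and 95%, a step of a number 2.7 percentage points lower from compound 2 to compound 4 (within the scatter) within the scatter.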

Compound 4, a percentage reported as activity, at one concentration (the size of the read-out at that concentration, not a potency): 86.6%
Beside the measured number, compound 4's estimate is 2.6 percentage points below it, and the stated range covers the measured number.
By their numbers in this assay, from the lowest: compounds 1, 4, 2 and 3 (each within the scatter of the next, the first and the last beyond it).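

Methoxy counts as a hydrogen-bond acceptor where fluoro does not, yet in this assay this change gives a number 0.1 percentage points lower from compound 2 to compound 4 (within the scatter). The comparisons with the other two groups also stay within the scatter, with a number 3.9 percentage points lower from compound 3 to compound 4 (within the scatter) and a number 8.8 percentage points higher from compound 1 to compound 4 (within the scatter), so an oxygen-linked group fits the narrow spread already seen at this position. No supporting data explain this outcome.

As far as these compounds go, it remains open whether an amine or a carboxylic acid on this aromatic carbon would leave this assay just as little changed.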